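The source may hold more compounds than are shown below. What is called first, only, known or untested is meant among the compounds shown, and "the series" means these compounds.

Measured so far:
compound 1 `Cc1nnsc1CO/N=C/c1c(C)nn(C)c1Oc1ccccc1Cl` gives 42500 nM
compound 2 `Cc1ccc(Oc2c(/C=N/OCc3snnc3C)c(C)nn2C)cc1` gives 13800 nM

Both compounds were tested in a functional assay on HCT-116 cells (Homo sapiens) for inhibition, read by MTT assay, with a stated time of 48 h; on this read-out higher numbers stand for weaker inhibition and lower numbers for stronger inhibition. Among the compounds with values here, compound 1 stands as the highest of the two numbers; its nearest neighbour is compound 2, and the gap between them, a 3.1-fold lower number from compound 1 to compound 2 (0.49 log units; beyond the scatter), is the one step known. That step exchanges the aryl group on the same oxygen, so it bears on the change considered here, though the entering group is not the same. Compound 3 `Cc1nnsc1CO/N=C/c1c(C)nn(C)c1Oc1cccc(F)c1F` differs from compound 1 in one place: 2,3-difluorophenyl in place of 2-chlorophenyl on an oxygen on an aromatic ring. Because a 3.1-fold lower number from compound 1 to compound 2 (0.49 log units; beyond the scatter) came from a different aryl exchange, the direction for compound 3 is uncertain; a step of modest size at most in this assay, in either direction, is expected. Compound 3 is therefore estimated at 30000 nM, with a range from 10000 nM to 90000 nM, which means an expected step of a 1.4-fold lower number from compound 1 to compound 3 (0.15 log units; within the scatter).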

Compound 3, half-maximal inhibitory concentration: 6560 nM
Compound 3: middle estimate off by 4.6-fold (0.66 log units), on the high side; the measured number lies below the stated range.
By their numbers in this assay, from the lowest: compound 3; then compound 2; then compound 1.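

In this assay, within the data shown here, replacing 2-chlorophenyl on the oxygen gives a 6.5-fold lower number from compound 1 to compound 3 (0.81 log units; beyond the scatter) and so shows that this place can move the read-out further than the one earlier exchange did. The further step of a 2.1-fold lower number from compound 2 to compound 3 (0.32 log units; beyond the scatter) puts 2,3-difluorophenyl lowest of the three aryl groups, and both exchanges lead downward from 2-chlorophenyl with no compound shown going against that. Nothing available here accounts for the differences among these aryl groups.

The compounds shown do not separate the contribution of each fluorine in 2,3-difluorophenyl, so a single-fluorine phenyl group remains the obvious open comparison. Also open, on these data alone, is how far the trend extends beyond halogen and methyl substituents on phenyl, for example to a methoxy-substituted phenyl, a pyridine ring, or a phenyl ring carrying a carboxylic acid.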